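The source may report more compounds than this note shows. Statements on the series, on what has been measured and on what is new or still open speak of the compounds shown alone.

In a functional assay on VCaP cells (Homo sapiens) for antiproliferative activity, read by propidium iodide staining, with a stated time of 96 h (on this read-out lower numbers stand for stronger inhibition and higher numbers for weaker inhibition), compound 1 (`CC(O)(CS(=O)(=O)c1cccc(C(F)(F)F)c1)C(=O)Nc1ccc(S(F)(F)(F)(F)F)cc1`) gives 32000 nM, while compound 2 (`CC(O)(CS(=O)(=O)c1ccc(OC(F)(F)F)cc1)C(=O)Nc1ccc(S(F)(F)(F)(F)F)cc1`) gives 95800 nM, the higher of the two numbers and so the weaker inhibition. Compound 3 (`CC(O)(CS(=O)(=O)c1ccccc1OC(F)(F)F)C(=O)Nc1ccc(S(F)(F)(F)(F)F)cc1`) has the same atoms as compound 2, joined differently: 2-(trifluoromethoxy)phenyl in place of 4-(trifluoromethoxy)phenyl on a sulfonyl sulfur. Among the measured compounds shown here, the one measured step that bears on this change is a 3.0-fold higher number from compound 1 to compound 2 (0.48 log units; beyond the scatter), a modest step that also alters the group on a sulfonyl sulfur. A step of similar modest size is therefore expected, leaning towards a lower number, though the direction is uncertain. The expected change is a 1.7-fold lower number from compound 2 to compound 3 (0.24 log units; within the scatter). The estimate for compound 3 is 55000 nM, with an expected range of 18000 nM to 140000 nM.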

Compound 3, half-maximal inhibitory concentration: 19900 nM
Estimate against measurement, compound 3: 2.8-fold (0.44 log units) above, within the range that was stated.
By their numbers in this assay, from the lowest: compounds 3 and 1 (each within the scatter of the next); then compound 2.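

Swapping 4-(trifluoromethoxy)phenyl for 2-(trifluoromethoxy)phenyl on the sulfonyl sulfur changes no atoms, yet it gives a 4.8-fold lower number from compound 2 to compound 3 (0.68 log units; beyond the scatter) and so shows that the arrangement of this group matters, not just its composition. Replacing 3-(trifluoromethyl)phenyl with the same 2-(trifluoromethoxy)phenyl gives a 1.6-fold lower number from compound 1 to compound 3 (0.21 log units; within the scatter), so these two compounds cannot be told apart. No measurement shown here explains the effect of this rearrangement.

The compounds shown leave open how a plain phenyl or a 2-(trifluoromethyl)phenyl group on the sulfonyl sulfur would compare. On these data alone, the effect of an amine or a carboxylic acid on that ring also remains open.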